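Three Inert Compounds and a Pyridinylmethyl Analogue

The source may report more compounds than this note shows. Statements on the series, on what has been measured and on what is new or still open speak of the compounds shown alone.

Compound 1 `COc1ccc(Nc2nc(/C=C/c3cc(OC)c(OC)c(OC)c3)nc3ccsc23)cc1`: in an ADME assay on RAW264.7 cells (Mus musculus) for cytotoxicity, read by MTT assay (on this read-out higher numbers stand for weaker inhibition and lower numbers for stronger inhibition), compound 1 gives > 50000 nM, which is a limit of the assay rather than a number.
Compound 2 `COc1cc(/C=C/c2nc(Nc3ccc(C(F)(F)F)cc3)c3sccc3n2)cc(OC)c1OC`: compound 2 gives > 50000 nM, again a limit.
Compound 3 `COc1cc(/C=C/c2nc(NCc3ccccc3)c3sccc3n2)cc(OC)c1OC`: compound 3 gives > 50000 nM, also a limit.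

Compound 2 therefore stands at the edge of what this assay reports, and so do the other two, as the limit of > 50000 nM in this assay, at which 3 of the 3 values shown sit, records. Every value is a limit. The steps a step that the two limits leave unreadable from compound 1 to compound 2, a step that the two limits leave unreadable from compound 1 to compound 3 and a step that the two limits leave unreadable from compound 2 to compound 3 have no readable size; they only show that swapping the group on the nitrogen, or changing a substituent on its aromatic ring, did not pull any compound into the measurable range.

Compound 4 `COc1cc(/C=C/c2nc(NCc3ccncc3)c3sccc3n2)cc(OC)c1OC` differs from compound 2 by (pyridin-4-yl)methyl in place of 4-(trifluoromethyl)phenyl on a nitrogen on an aromatic ring. The changes on the same nitrogen that were measured bear on this, and none of them became readable, so the expected outcome for compound 4 is that it, too, stays at the limit, with no step beyond the scatter. For compound 4 the expected step is a step that the limit leaves unreadable from compound 2 to compound 4. The estimate for compound 4 is 70000 nM, with a range from 30000 nM to 200000 nM.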

Compound 4, half-maximal inhibitory concentration: > 50000 nM
Compound 4: a limit, no number; the forecaster's own chance of this, stated with the estimate: 85%; the middle value does not contradict the limit.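

Compound 4 also gives only a limit in this assay, so its steps from compound 1, compound 2 and compound 3 cannot be read. All four results stand at the same edge of the assay: the limit of > 50000 nM in this assay, at which 4 of the 4 values shown sit.

The compounds shown leave open what the actual value of each one is, and whether any other group on the shared core would give a readable number.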